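From compound 1 to compound 4: a solubility estimate

The compounds below may be only part of what the source reports. "The series", "measured", "known", "first", "only" and "open" are said of these compounds alone.

Measured so far in a physicochemical assay for solubility, read by nephelometry, measured as kinetic solubility, at pH 6.5 (a lower number here means a less soluble compound, a higher number a more soluble compound), with these results:
- compound 1 `CN(C)Cc1csc(NC(=O)c2cc(C(C)(C)C)nn2Cc2ccccc2)n1` gives 25 ug/mL
- compound 2 `CC(C)(C)c1cc(C(=O)Nc2nc(CNS(C)(=O)=O)cs2)n(Cc2ccccc2)n1` gives 3.1 ug/mL
- compound 3 `NCc1csc(NC(=O)c2ccn[nH]2)n1` gives > 100 ug/mL (a limit, not a number)

Of the two exact numbers, compound 1 stands highest. Going by the values given here, compound 3 reports only a limit and no single step ties it to the others. Compound 4 `CC(C)(C)c1cc(C(=O)Nc2cccnc2)n(Cc2ccccc2)n1` is not yet measured. It carries pyridin-3-yl in place of 4-((dimethylamino)methyl)-1,3-thiazol-2-yl on an amide-type nitrogen. Compound 2 also gives up the dimethylamino group, in a modest step of an 8.1-fold lower number from compound 1 to compound 2 (0.91 log units; beyond the scatter) so a lower number is expected for compound 4 in this assay too, perhaps by less. The expected change is an estimated 3.1-fold lower number from compound 1 to compound 4 (0.49 log units; beyond the scatter) in this direction. For compound 4 the estimate is 8 ug/mL with a range of 2 ug/mL to 30 ug/mL around it.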

Compound 4, solubility: 6.3 ug/mL
Estimate against measurement, compound 4: 1.3-fold (0.10 log units) above; low and high end bracket the measured number.
By their numbers in this assay, from the lowest: compound 2; then compound 4; then compound 1. At a limit, above all of these: compound 3.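

Exchanging the whole group on the amide-type nitrogen for pyridin-3-yl gives a 4.0-fold lower number from compound 1 to compound 4 (0.60 log units; beyond the scatter) in this assay. The number therefore moves with the ring at this position as well as with the end of the chain changed in compound 2, and a ring without the dimethylamino group still stays below compound 1. No measurement shown here accounts for this drop.

This step removes the thiazole ring and the dimethylamino group together, so their shares remain unseparated. A pyridin-3-yl ring carrying a dimethylaminomethyl chain would tell them apart.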